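The source may report more compounds than this note shows. Statements on the series, on what has been measured and on what is new or still open speak of the compounds shown alone.

Three ureas carrying the same basic core have been measured in an assay on CHO cells for displacement of a labelled ligand from histamine receptor H3 (Macaca mulatta), read by scintillation counting, with a stated time of 1 h; a higher number here means a weaker inhibitor, a lower number a stronger inhibitor. Compound 1 `Cc1cc(N2CCC(N3CCCC3C)C2)ccc1NC(=O)NC1CCCCC1` gives 4.6 nM. Compound 2 `Cc1cc(NC(=O)NC2CCCCC2)ccc1N1CCC(N2CCCC2C)C1`, in which the methyl group on the aromatic ring sits at a different position of the same core, gives 11.2 nM. Compound 3 `CC1CCCN1C1CCN(c2ccc(NC(=O)N3CCN(c4ccccc4)CC3)cc2)C1`, whose urea is closed onto a phenyl-substituted piperazine, gives 10.6 nM. Among these three, compound 2 carries the highest number: its gap to compound 3 is within the usual scatter, so the two cannot be told apart, while compound 1 sits clearly lower, beyond the scatter.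

Compound 4 `Cc1cc(NC(=O)NCc2cccs2)ccc1N1CCC(N2CCCC2C)C1` has not yet been measured in this assay. It is built from compound 2 by a single change at the far end of the urea: (thiophen-2-yl)methyl in place of cyclohexyl on an amide-type nitrogen. For the measured compounds named here, no pair among the measured compounds shows this particular exchange, so there is no measured step to lean on; the nearest information is that compound 2 and compound 3, with quite different urea termini, give numbers that are indistinguishable. On that basis compound 4 is expected to stay close to compound 2, with the step of a 1.3-fold higher number from compound 2 to compound 4 (0.13 log units; within the scatter) estimated to be small and possibly upward, within or only just beyond the scatter. The estimate for compound 4 in this assay is 15 nM, with a range from 5 nM to 45 nM.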

Compound 4, inhibition constant: 8.4 nM
The estimate for compound 4 lay 1.8-fold (0.25 log units) above the measured number; the range from low to high includes it.
By their numbers in this assay, from the lowest: compounds 1, 4, 3 and 2 (each within the scatter of the next, the first and the last beyond it).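

In this assay, putting (thiophen-2-yl)methyl in place of cyclohexyl on the amide-type nitrogen gives a 1.3-fold lower number from compound 2 to compound 4 (0.12 log units; within the scatter), so compound 2 and compound 4 cannot be told apart. The earlier compounds shown here offered no pair differing at this place alone; this pair shows that a five-membered aromatic ring with one hetero atom can replace a six-membered non-aromatic ring of carbon only, at the same count of heavy atoms, without a readable shift in the number. Nothing measured here bears on why the two compounds stay within the scatter of each other.

From the compounds shown here alone, whether a benzyl group, a longer chain ending in the same thiophene, or a carboxylic acid at this end of the urea would also stay within the scatter of compound 2 remains open, since one exchange does not mark the limits of this position. Also open, going by these compounds, is whether the same exchange would give a step of similar size on the core of compound 1, which has the methyl group at a different position and gives 4.6 nM.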